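This account rests on a few compounds, and the source may have more. Where it says the series, first, only, none or still open, it means among the compounds named here.

Measured so far:
compound 1, `CCCC[C@H](NC(=O)[C@H](CCCCN)NC(=O)[C@H](CCCNC(=N)N)NC(=O)c1ccc(/C=C/C(N)=O)cc1)C(N)=O` — "impermeable" (no number reported) in an ADME assay for permeability, using PAMPA; on this read-out higher numbers stand for higher permeability and lower numbers for lower permeability
compound 2, `CCCC[C@H](NC(=O)[C@H](CCCCN)NC(=O)[C@H](CCCNC(=N)N)NC(=O)c1ccc(/C=C2\SC(=O)N(Cc3ccc(F)cc3)C2=O)cc1)C(N)=O` — 0.43 10^-6 cm/s
compound 3, `CCCC[C@H](NC(=O)[C@H](CCCCN)NC(=O)[C@H](CCCNC(=N)N)NC(=O)c1ccc(/C=C2\SC(=S)N(c3ccc(Cl)cc3)C2=O)cc1)C(N)=O` — 1.02 10^-6 cm/s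

Compound 1 gives no number in this assay, only the word recorded for it. Of the two numbers that exist, compound 2 holds the lower one, and compound 3 stands above it by a gap that lies beyond the scatter. Compound 4, `CCCC[C@H](NC(=O)[C@H](CCCCN)NC(=O)[C@H](CCCNC(=N)N)NC(=O)c1ccc(/C=C2\SC(=O)N(C3CCCCC3)C2=O)cc1)C(N)=O`, is not yet measured. It differs from compound 2 in one place: cyclohexyl in place of 4-fluorobenzyl on an amide-type nitrogen in a ring. For the measured compounds named here, no measured pair shows this change, so the data give no size for it. The expectation is a step close to none beyond the scatter, from compound 2 to compound 4 estimated at a 1.1-fold lower number from compound 2 to compound 4 (0.03 log units; within the scatter). Compound 4 is therefore expected to give about 0.4 10^-6 cm/s, within 0.15 10^-6 cm/s to 1.1 10^-6 cm/s.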

Compound 4, apparent permeability: 1.69 10^-6 cm/s
For compound 4 the middle estimate is 4.2-fold (0.63 log units) below the measured one, and the stated range ends below it.
By their numbers in this assay, from the lowest: compound 2; then compounds 3 and 4 (each within the scatter of the next).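

On the ring nitrogen, the group clearly matters in this assay: cyclohexyl in place of 4-fluorobenzyl gives a 3.9-fold higher number from compound 2 to compound 4 (0.59 log units; beyond the scatter). A non-aromatic carbon ring can therefore take this place without loss on this read-out, although the whole 4-fluorobenzyl group leaves at once, so no single part of it can be singled out. Nothing measured here explains the step. Still open, as far as these compounds go, is how an amine, a carboxylic acid or a longer carbon chain on this nitrogen would read. Also open, from the compounds shown here alone, is whether the same change gives a similar step on the core of compound 3.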